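This account rests on a few compounds, and the source may have more. Where it says the series, first, only, none or still open, it means among the compounds named here.

compound 1 `CN1CCC=C(c2ccc(CN(C)Cc3ccccc3)cc2)C1`: "not determined" (no result reported)
compound 2 `CN1CCC=C(c2ccc(CN(C)Cc3ccc(Cl)cc3)cc2)C1`: 2140 nM

In a functional assay on HL-60 cells (Homo sapiens) for inhibition (a lower number here means a stronger inhibitor, a higher number a weaker inhibitor), compound 2 gives 2140 nM. For the measured compounds named here, this is the only number so far, so compound 2 cannot yet be ranked, and compound 1 offers no comparison. Compound 3 `CN1CCC=C(c2ccc(CN(C)C/C=C/c3ccccc3)cc2)C1` is still unmeasured. It keeps the core of compound 2 and carries 2-phenylethenyl in place of 4-chlorophenyl on a saturated chain carbon bound to an amine nitrogen. Going by the values given here, the series holds no measured step to size such a change, so the expectation is loose. In this assay no step beyond the scatter is expected, with only a slight lean towards weaker inhibition from compound 2 at 2140 nM. The expected change is a 1.2-fold higher number from compound 2 to compound 3 (0.07 log units; within the scatter). For compound 3 the estimated value is 2500 nM, with an expected range of 700 nM to 9000 nM.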

Compound 3, half-maximal inhibitory concentration: 680 nM
Estimate against measurement, compound 3: 3.7-fold (0.57 log units) above; measured number outside the range, below it.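

In this assay, for the compounds shown here, the place on a saturated chain carbon bound to an amine nitrogen proves responsive to substitution: 2-phenylethenyl in place of 4-chlorophenyl gives a 3.1-fold lower number from compound 2 to compound 3 (0.50 log units; beyond the scatter), the first step that can be read. The change is not a single one, as the chlorine leaves, one double bond outside aromatic rings enters, and the six-membered aromatic ring of carbon only stays. No supporting data bear on why the number falls.

This single step leaves open whether the gain follows the double bond or the loss of the chlorine. A 2-phenylethyl group at this place, or 4-chlorophenylethenyl carrying both features, would separate the two contributions.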